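Three Inactive Analogues and a Halogenated Fourth

The source may report more compounds than this note shows. Statements on the series, on what has been measured and on what is new or still open speak of the compounds shown alone.

In a functional assay on MCF7 cells (Homo sapiens) for cytotoxicity, read by MTT assay, with a stated time of 72 h (a higher number here means a weaker inhibitor, a lower number a stronger inhibitor), the measured compounds stand as follows:
compound 1 `FC(F)(F)c1ccc(CSc2nc(Nc3ccccc3C(F)(F)F)c3ccccc3n2)cc1` gives > 50000 nM, a limit of the assay.
compound 2 `FC(F)(F)c1ccc(CSc2nc(Nc3ccccc3Cl)c3ccccc3n2)cc1` gives > 50000 nM, a limit of the assay.
compound 3 `COc1ccc(Nc2nc(SCc3ccc(C(F)(F)F)cc3)nc3ccccc23)cc1OC` gives > 50000 nM, a limit of the assay.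

Compound 3 therefore stands at the limit of > 50000 nM in this assay, at which 3 of the 3 values shown sit, with no number of its own. Compound 4 `Fc1ccc(Nc2nc(SCc3ccc(C(F)(F)F)cc3)nc3ccccc23)cc1Cl` differs from it by 3-chloro-4-fluorophenyl in place of 3,4-dimethoxyphenyl on a nitrogen on an aromatic ring. Within the data shown here, the steps that bear on this position, a step that the two limits leave unreadable from compound 1 to compound 3 and a step that the two limits leave unreadable from compound 2 to compound 3, are both unreadable in size, and a step that the two limits leave unreadable from compound 1 to compound 2 is likewise unreadable. Among the measured compounds shown here, no measured step gives a direction for this assay, so no step beyond the scatter is expected, and compound 4 is expected to remain at or near the limit. Compound 4 is estimated at 50000 nM, within 10000 nM to 200000 nM, which means an expected step of a number no higher from compound 3 to compound 4 (the limit leaves the size open).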

Compound 4, half-maximal inhibitory concentration: 23000 nM
For compound 4 the middle estimate is 2.2-fold (0.34 log units) above the measured one; the range from low to high includes it.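

In this assay, compound 4 is the first compound shown to give a number rather than a limit, so the group on this nitrogen can move the read-out: the limit of > 50000 nM in this assay, at which 3 of the 4 values shown sit. Setting 3-chloro-4-fluorophenyl in place of 3,4-dimethoxyphenyl gives an at least 2.1-fold lower number from compound 3 to compound 4 (0.33 log units; beyond the scatter), and replacing the two other aryl groups gives an at least 2.1-fold lower number from compound 2 to compound 4 (0.33 log units; beyond the scatter) and an at least 2.1-fold lower number from compound 1 to compound 4 (0.33 log units; beyond the scatter).

From the compounds shown here alone, whether the chloro or the fluoro alone would suffice remains open. So does the effect of an amine or a carboxylic acid on this phenyl ring.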